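Isopropylsulfanyl for methyl in a guanidinocarbonyl benzene series

The source may hold more compounds than are shown below. What is called first, only, known or untested is meant among the compounds shown, and "the series" means these compounds.

Measured so far in a functional assay for inhibition of sodium/hydrogen exchanger (Oryctolagus cuniculus); a lower number here means a stronger inhibitor, a higher number a weaker inhibitor:
compound 1 `Cc1c(C(=O)N=C(N)N)ccc(Cl)c1S(C)(=O)=O`: 1300 nM
compound 2 `Cc1cc(C)c(S(C)(=O)=O)cc1C(=O)N=C(N)N`: 11 nM
compound 3 `Cc1c(C(=O)N=C(N)N)cc(S(C)(=O)=O)c(C)c1C`: 55 nM

Compound 2 gives the lowest number of the three in this assay; the nearest is compound 3, and the step of a 5.0-fold higher number from compound 2 to compound 3 (0.70 log units; beyond the scatter) is a modest one. For the measured compounds named here, compound 1 lies much further off, the two values showing a large gap, though no single-place step connects it to compound 2.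

The next compound, compound 4 `Cc1cc(SC(C)C)c(S(C)(=O)=O)cc1C(=O)N=C(N)N`, differs from compound 2 in one place: isopropylsulfanyl in place of methyl on an aromatic carbon.

Going by the values given here, only one measured step exists, and it concerns a methyl entering at a different aromatic carbon, so it bears on this change only loosely; the step from compound 2 to compound 3 shows that adding a group on the ring can cost potency modestly. Among the compounds with values here, no measured pair exchanges a methyl for a sulfur-linked chain. The expectation for compound 4 is therefore a step of a 1.4-fold higher number from compound 2 to compound 4 (0.13 log units; within the scatter), close to the scatter and without a firm direction. Compound 4 is expected to give about 15 nM, with a range from 4 nM to 60 nM.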

Compound 4, half-maximal inhibitory concentration: 12 nM
Beside the measured number, compound 4's estimate is 1.3-fold (0.10 log units) above it; the range from low to high includes it.
By their numbers in this assay, from the lowest: compounds 2 and 4 (each within the scatter of the next); then compound 3; then compound 1.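

In this assay isopropylsulfanyl, of 4 heavy atoms, replaces methyl, of 1 heavy atom, on the aromatic carbon ortho to a methylsulfonyl group with a 1.1-fold higher number from compound 2 to compound 4 (0.04 log units; within the scatter) and so without a change that stands out from the scatter, which shows that this position accepts the longer sulfur-linked group in this assay. The only earlier step, a 5.0-fold higher number from compound 2 to compound 3 (0.70 log units; beyond the scatter) on adding a methyl at a different aromatic carbon, lies beyond the scatter, so among these compounds a change on the ring does not carry one fixed cost from place to place. No measurement is at hand that would explain this result. Going by these compounds, whether the position accepts other kinds of group, such as an amine, a carboxylic acid or a longer alkyl chain on sulfur, remains open. Also open, on these data alone, is whether isopropylsulfanyl would read the same on the core of compound 3.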